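Methylating the Aromatic Amine of Compound 2

The compounds below may be only part of what the source reports. "The series", "measured", "known", "first", "only" and "open" are said of these compounds alone.

Of the compounds shown here, two sharing one core have been measured in a functional assay on UV4 cells (Cricetulus griseus) for cytotoxicity, with a stated time of 4 h; on this read-out lower numbers stand for stronger inhibition and higher numbers for weaker inhibition. Compound 1 `CS(=O)(=O)N1CC(CCl)c2ccc(O)cc21` carries a hydroxy group on the aromatic ring, and in this assay compound 1 gives 1900 nM. Compound 2 `CS(=O)(=O)N1CC(CCl)c2ccc(N)cc21` has an amino group in that place instead, and in this assay compound 2 gives 13000 nM. Among the measured compounds shown here, the single step between them, a 6.8-fold higher number from compound 1 to compound 2 (0.84 log units; beyond the scatter), is the only measured comparison so far, so compound 2 stands with the highest number of the two, its nearest neighbour being compound 1 at the lower number.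

Compound 3 `CNc1ccc2c(c1)N(S(C)(=O)=O)CC2CCl` is not yet measured. It differs from compound 2 by methyl in place of hydrogen on a nitrogen on an aromatic ring, so the amino group becomes a methylamino group. For the measured compounds named here, no measured step covers this kind of change: the one step known, a hydroxy exchanged for an amino group, concerns a different exchange and gives no guide to adding a methyl on the nitrogen. With nothing pointing in either direction, the expected step of a 1.3-fold lower number from compound 2 to compound 3 (0.11 log units; within the scatter) is small and may lie within the scatter. Compound 3 is therefore estimated at 10000 nM, with a range from 3000 nM to 40000 nM.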

Compound 3, half-maximal inhibitory concentration: 4100 nM
Estimate against measurement, compound 3: 2.4-fold (0.39 log units) above; measured number inside the range.
By their numbers in this assay, from the lowest: compound 1; then compound 3; then compound 2.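

In this assay, one methyl on the nitrogen on an aromatic ring is enough to shift the result, giving a 3.2-fold lower number from compound 2 to compound 3 (0.50 log units; beyond the scatter), so this position responds to a change as small as amino to methylamino, and the response is toward stronger inhibition. The methylamino group still falls short of the hydroxy group, with a 2.2-fold higher number from compound 1 to compound 3 (0.33 log units; beyond the scatter), so the methyl closes only part of the gap opened by a 6.8-fold higher number from compound 1 to compound 2 (0.84 log units; beyond the scatter), and the three groups at this place rank hydroxy, then methylamino, then amino. No measurement available here explains why the methyl shifts the result in this direction.

Still open, on these data alone, is whether the trend continues with a dimethylamino group, or with an ethylamino group, which has a longer chain on the same nitrogen. A methoxy group in the same place would show whether a methyl on the oxygen of compound 1 shifts the result as a methyl on the nitrogen does.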